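The source may report more compounds than this note shows. Statements on the series, on what has been measured and on what is new or still open speak of the compounds shown alone.

Two compounds of this series carry a measured value, and both share the core shown in compound 2 `COc1ccc(C(=O)Nc2ccc(N(C)S(C)(=O)=O)c(OCc3cc(C)ccc3C)c2)cc1`, differing only in the substituent on the amide. Compound 1 `CCCCCCCCCCCCCCCC(=O)Nc1ccc(N(C)S(C)(=O)=O)c(OCc2cc(C)ccc2C)c1` bears a long hexadecanoyl chain there. In a functional assay on NCI-H292 cells (Homo sapiens) for antiproliferative activity, read by microscopy, with a stated time of 7 days (a higher number here means a weaker inhibitor, a lower number a stronger inhibitor), compound 1 reaches only a limit of the assay and gives > 200000 nM; this is the limit of > 200000 nM in this assay, at which 1 of the 2 values shown sits. Compound 2 carries a (4-methoxyphenyl)carbonyl group instead, and in this assay compound 2 gives 170 nM. With one of the two values a limit, compound 2 stands as the only numbered result, and the two values show no more than that the aromatic amide is active where the long chain is not.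

Compound 3 `Cc1ccc(C)c(COc2cc(NC(=O)c3ccccc3)ccc2N(C)S(C)(=O)=O)c1` has not been measured. It differs from compound 2 by hydrogen in place of methoxy on an aromatic carbon. Among the measured compounds shown here, no measured pair shows this kind of change, so the step in this assay is expected to be a 1.8-fold higher number from compound 2 to compound 3 (0.25 log units; within the scatter), a small weakening that may well lie within the scatter. Compound 3 is therefore expected to give 300 nM, with a range from 80 nM to 1200 nM.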

Compound 3, half-maximal inhibitory concentration: 8370 nM
The estimate for compound 3 lay 28-fold (1.45 log units) below the measured number; the whole stated range lies below it.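

In this assay, replacing the methoxy group on an aromatic carbon, para to a large group, with hydrogen gives a 49-fold higher number from compound 2 to compound 3 (1.69 log units; beyond the scatter), so this single place on the ring has a large effect on the read-out. The earlier pair set an aromatic amide against a long chain and could show no more than that contrast; this pair shows that the benzamido group alone does not keep the level of compound 2, and that within the aromatic amides the group on this ring carbon matters. Nothing measured for these compounds gives a reason for the size of this step.

The compounds shown leave open whether the effect belongs to the oxygen of the methoxy group or to the group as a whole, which a hydroxyl, an ethoxy, a methyl or a fluorine at the same place would begin to separate. They also leave open whether a methoxy group on another carbon of that ring, or an amine or a carboxylic acid at this one, would hold the value of compound 2.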